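Swapping a Butyl Chain for Two Carbons and Two Sulfurs

The source may report more compounds than this note shows. Statements on the series, on what has been measured and on what is new or still open speak of the compounds shown alone.

Three related compounds have been tested in an ADME assay on HeLa cells (Homo sapiens) for cytotoxicity, read by MTT assay, with a stated time of 24 h; a higher number here means a weaker inhibitor, a lower number a stronger inhibitor. Compound 1 `CN(C)C(=S)SC(=S)N1CCCCCC1` reaches only a limit of the method, and in this assay compound 1 gives > 5000000 nM. Compound 2 `CCN(CC)C(=S)SC(=S)N(C)C` likewise stops at a limit, and compound 2 gives > 5000000 nM. Within the data shown here, compound 3 `CCCCN1CCN(C(=S)SC(=S)N(C)C)CC1` is the only one with a measured number, and in this assay compound 3 gives 4100000 nM, so it stands alone as the one real value, the other two sitting at the limit of > 5000000 nM in this assay, at which 2 of the 3 values shown sit.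

Compound 4 `CSC(=S)N1CCN(C(=S)SC(=S)N(C)C)CC1` is not yet measured. It differs from compound 3 by a group of 4 heavy atoms (2 carbon, 2 sulfur; no ring) in place of a group of 4 heavy atoms (4 carbon; no ring), on an amine nitrogen in a ring. Among the measured compounds shown here, no measured pair shows what such a change does here, so the expected step of a 1.1-fold higher number from compound 3 to compound 4 (0.04 log units; within the scatter) is small, not beyond the usual scatter. Compound 4 is therefore estimated at 4500000 nM, between 2000000 nM and 10000000 nM, with a fair chance that only a limit is reported.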

Compound 4, half-maximal inhibitory concentration: > 5000000 nM
Compound 4 gave a limit, no number; the forecaster's own chance of this, stated with the estimate: 50%; middle value at least 1.1-fold (0.04 log units) from the limit.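

On the amine nitrogen in the ring, putting the group of 2 carbon and 2 sulfur atoms in place of butyl leaves compound 4 at a limit of the method: the limit of > 5000000 nM in this assay, at which 3 of the 4 values shown sit. In this assay, this swap gives an at least 1.2-fold higher number from compound 3 to compound 4 (0.08 log units; that floor lies within the scatter). Only the floor of that step can be read, so its true size stays unknown, and this position has not yet shown a change beyond the usual scatter.

From the compounds shown here alone, whether an amine, a carboxylic acid or a chain longer than butyl on this nitrogen would give a clearly lower number stays open. A clearly higher number cannot be seen here at all, as only a limit is reported at that end.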